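Compound 3 to compound 4: methoxy to hydroxy

A few compounds are considered here, and "the series" means these few. Any claim that something is new, unique, unknown or untested is made for them only; others in the source may bear on it.

In a functional assay on A549 cells (Homo sapiens) for antiproliferative activity, read by MTT assay, with a stated time of 48 h (on this read-out higher numbers stand for weaker inhibition and lower numbers for stronger inhibition), compound 1 (`COc1cccc(C(=O)Nc2nnc(/C=C/c3cc(OC)c(OC)c(OC)c3Br)s2)c1`) gives 60 nM, compound 2 (`COc1cc(/C=C/c2nnc(NC(=O)c3cccc(O)c3)s2)c(Br)c(OC)c1OC`) gives 120 nM and compound 3 (`COc1cccc(C(=O)Nc2nnc(/C=C/c3cc(OC)c(OC)c(OC)c3)s2)c1`) gives 150 nM. The number for compound 3 lies within the scatter of the number for compound 2. Its separation from the bromo-bearing compound 1 is larger, and the record for hydrogen in place of bromo on an aromatic carbon reads a 2.5-fold higher number from compound 1 to compound 3 (0.40 log units; beyond the scatter).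

Compound 4 (`COc1cc(/C=C/c2nnc(NC(=O)c3cccc(O)c3)s2)cc(OC)c1OC`) has not been measured. It differs from compound 3 by hydrogen in place of methyl on an oxygen on an aromatic ring, which turns 3-methoxyphenyl into 3-hydroxyphenyl. This is hydrogen in place of methyl on an oxygen on an aromatic ring.

Among the measured compounds shown here, only one measured step makes the same replacement: a 2.0-fold higher number from compound 1 to compound 2 (0.30 log units; within the scatter). That step was taken with bromo present, and the data do not show whether it carries over to a compound without bromo. The bromo step is a different change and gives no direct guide here. For the measured compounds named here, a small rise in the number is therefore expected in this assay, following the direction of the single precedent, with no firm expectation of a shift beyond the scatter. The expected step is a 1.7-fold higher number from compound 3 to compound 4 (0.24 log units; within the scatter). The estimate for compound 4 is 260 nM, with an expected range of 120 nM to 550 nM.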

Compound 4, half-maximal inhibitory concentration: 190 nM
For compound 4 the middle estimate is 1.4-fold (0.14 log units) above the measured one; measured number inside the range.
By their numbers in this assay, from the lowest: compounds 1, 2, 3 and 4 (each within the scatter of the next, the first and the last beyond it).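

In this assay, the swap of methoxy for hydroxy on the 3-methoxyphenyl group can now be read without bromo on the core, and a 1.3-fold higher number from compound 3 to compound 4 (0.10 log units; within the scatter). The change has thus been read on two cores, and neither step leaves the scatter, so at this position hydroxy and methoxy are not told apart in either setting, and the two readings agree with each other: the same change on two cores in this assay, a 2.0-fold higher number (0.30 log units; within the scatter) from compound 1 to compound 2 and a 1.3-fold higher number (0.10 log units; within the scatter) from compound 3 to compound 4, 1.6-fold (0.20 log units) apart, within the scatter of two such steps. The bromo change also gains a second reading, with hydroxy in place of methoxy, where a 1.6-fold higher number from compound 2 to compound 4 (0.20 log units; within the scatter), so the earlier step beyond the scatter is not repeated, although the two readings do not differ beyond the scatter: the same change on two cores in this assay, a 2.5-fold higher number (0.40 log units; beyond the scatter) from compound 1 to compound 3 and a 1.6-fold higher number (0.20 log units; within the scatter) from compound 2 to compound 4, 1.6-fold (0.20 log units) apart, within the scatter of two such steps.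

Open, as far as these compounds go, is whether any group at this oxygen or in its place moves the number beyond the scatter, for example an ethoxy group, a longer alkoxy chain, an amine or a carboxylic acid on the same aromatic ring. Also open, from the compounds shown here alone, is whether chloro in place of bromo on the aromatic carbon of the shared core would give a number closer to that of compound 1 or to that of compound 3.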